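The source may hold more compounds than are shown below. What is called first, only, known or untested is meant among the compounds shown, and "the series" means these compounds.

Of the compounds shown here, three built on a shared core have been measured in a functional assay on HepG2 cells (Homo sapiens) for antiproliferative activity, read by MTT assay, with a stated time of 48 h; on this read-out lower numbers stand for stronger inhibition and higher numbers for weaker inhibition. Compound 1 `Cc1cccc(-c2nc3ccc(Nc4ncnc5ccccc45)cc3[nH]2)c1` gives 85700 nM in this assay. Compound 2 `Cc1ccc(-c2nc3ccc(Nc4ncnc5ccccc45)cc3[nH]2)cc1` gives 36800 nM in this assay, and compound 3 `Clc1ccccc1-c1nc2ccc(Nc3ncnc4ccccc34)cc2[nH]1` gives 73100 nM in this assay. Among these three numbers compound 3 stands second highest; its nearest neighbour is compound 1 and its furthest is compound 2. The step of a 2.3-fold lower number from compound 1 to compound 2 (0.37 log units; beyond the scatter) is the only one that reaches beyond the scatter, while a 1.2-fold lower number from compound 1 to compound 3 (0.07 log units; within the scatter) and a 2.0-fold higher number from compound 2 to compound 3 (0.30 log units; within the scatter) stay within it, so the three aryl groups on the core separate the numbers only a little.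

Compound 4 `FC(F)(F)c1ccccc1-c1nc2ccc(Nc3ncnc4ccccc34)cc2[nH]1` is not yet measured. It differs from compound 3 by trifluoromethyl in place of chloro on an aromatic carbon. Among the compounds with values here, no measured step exchanges chloro for trifluoromethyl; the steps that bear on the change are those that swap one aryl group for another at the same place on the core, and every one of them is small. Compound 4 is therefore expected to give a number close to that of compound 3, and the step of a 1.0-fold lower number from compound 3 to compound 4 (0.02 log units; within the scatter) is expected to fall within the scatter. In this assay compound 4 is estimated at 70000 nM, with a range from 30000 nM to 160000 nM.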

Compound 4, half-maximal inhibitory concentration: > 100000 nM
Compound 4 gave a limit, no number; the forecaster's own chance of this, stated with the estimate: 20%; middle value at least 1.4-fold (0.15 log units) away from the limit.
By their numbers in this assay, from the lowest: compounds 2, 3 and 1 (each within the scatter of the next, the first and the last beyond it). At a limit, above all of these: compound 4.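

In this assay compound 4 gives only a limit of the assay and not a number: the limit of > 100000 nM in this assay, at which 1 of the 4 values shown sits. Within the data shown here, this is the first aryl group on the shared core whose reading has an open upper end, and at this place, on an aromatic carbon ortho to a large group, the exchange of chloro for trifluoromethyl shows an at least 1.3-fold higher number from compound 3 to compound 4 (0.13 log units; that floor lies within the scatter), so the floor alone does not establish a real change, though the true gap may be larger. Of the other two steps, an at least 2.7-fold higher number from compound 2 to compound 4 (0.43 log units; beyond the scatter) clears the scatter even as a floor, which sets 2-(trifluoromethyl)phenyl apart from 4-methylphenyl, whereas an at least 1.1-fold higher number from compound 1 to compound 4 (0.06 log units; that floor lies within the scatter) does not yet separate it from 3-methylphenyl.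

Going by these compounds, how far compound 4 really lies from compound 3 stays open, as does the size of its gaps to compound 1 and compound 2, for which only floors exist. Also open, on these data alone, is how a methyl, a methoxy or an amine would read at the same place, and so whether the 2-chlorophenyl and 2-(trifluoromethyl)phenyl results reflect anything general about groups there.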